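The compounds below may be only part of what the source reports. "The series", "measured", "known", "first", "only" and "open" are said of these compounds alone.

In an assay on isolated protein for inhibition of histone deacetylase 8 (Homo sapiens), read by fluorescence, with a stated time of 90 min (on this read-out higher numbers stand for weaker inhibition and lower numbers for stronger inhibition), compound 1 `O=C(NO)c1coc(-c2ccccc2)n1` gives 41900 nM, the highest of the three numbers recorded so far. Compound 3 `O=C(NO)c1coc(-c2cccs2)n1` gives 8130 nM in this assay, and compound 2 `O=C(NO)c1coc(C(c2ccccc2)c2ccccc2)n1` gives 2700 nM, so compound 1 sits apart from both of them, beyond the usual scatter, at the weak end of the set.

Compound 4 `O=C(NO)c1coc(-c2ccccc2Br)n1` has not yet been measured. It differs from compound 1 in one place: bromo in place of hydrogen on an aromatic carbon, on an aromatic carbon of a six-membered aromatic ring of carbon only, ortho to a group of 9 heavy atoms. For the measured compounds named here, no measured pair in this set shows what such a change does, so the size of the step is open. The two compounds that depart from the plain phenyl of compound 1, compound 2 and compound 3, both give lower numbers, which leaves room for a modest gain.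

Compound 4 is therefore expected to give about 15000 nM in this assay, within a range from 4000 nM to 60000 nM, an expected step of a 2.8-fold lower number from compound 1 to compound 4 (0.45 log units; beyond the scatter) that may or may not clear the scatter.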

Compound 4, half-maximal inhibitory concentration: 20200 nM
Beside the measured number, compound 4's estimate is 1.3-fold (0.13 log units) below it; the measured number falls inside the stated range.
By their numbers in this assay, from the lowest: compound 2; then compound 3; then compound 4; then compound 1.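

In this assay, bromo in place of hydrogen on an aromatic carbon gives a 2.1-fold lower number from compound 1 to compound 4 (0.32 log units; beyond the scatter), a modest step and the only one in this set that isolates a single change. It shows that a bromo can stand on this carbon of the six-membered aromatic ring of carbon only, ortho to a group of 9 heavy atoms, without loss of inhibition, and that the number moves toward stronger inhibition. Nothing measured here explains the step, so it can be described but not accounted for.

The compounds shown leave open whether the step is specific to bromo or would also appear with chloro, methyl or methoxy on the same carbon. They also leave open what a bromo would do on the other carbons of that ring.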